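The source may hold more compounds than are shown below. What is called first, only, known or untested is meant among the compounds shown, and "the series" means these compounds.

Of the compounds shown here, three have so far been tested in a functional assay on the whole organism (Tail, strain ICR) with Mus musculus as the target, in the tail flick test, with a stated time of 120 min, at a dose of 25 umol/kg by the oral route; a lower number here means a weaker effect, a higher number a stronger effect of the compound at the dose given. Compound 1 `NC(=O)CC[C@H](NC(=O)CN(c1ncnc2c1ncn2C1CCCCO1)C1CC1)C(=O)OCc1ccccc1` gives 22.3%. Compound 2 `O=C(O)[C@@H]1CCCN1C(=O)CN(c1nc(Cl)nc2[nH]cnc12)C1CC1` gives 23.6%, and compound 3 `O=C(CN(c1nc(Cl)nc2[nH]cnc12)C1CC1)NCC(=O)OCc1ccccc1` gives 21.7%. On these numbers compound 1 stands second highest of the three, yet its gap to compound 3 and its gap to compound 2 both lie within the scatter of repeated measurements, so the three read as alike. Compound 4 `O=C(CN(c1ncnc2c1ncn2C1CCCCO1)C1CC1)N[C@@H](CCC(=O)OCc1ccccc1)C(=O)OCc1ccccc1` has not yet been measured. It differs from compound 1 in one place: benzyloxy in place of amino on a carbonyl carbon. With all three measured values so close together, no step beyond the scatter is expected from this change in this assay. The expected change is estimated at a number 0.3 percentage points lower from compound 1 to compound 4 (within the scatter). Compound 4 is thus expected to give about 22%, within a range from 12% to 33%.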

Compound 4, a percentage reported as activity, at one dose (the size of the read-out at that dose, not a potency): 20.7%
Estimate against measurement, compound 4: 1.3 percentage points above, within the range that was stated.
By their numbers in this assay, from the lowest: compounds 4, 3, 1 and 2 (each within the scatter of the next).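

In this assay, benzyloxy in place of amino on a carbonyl carbon gives a number 1.6 percentage points lower from compound 1 to compound 4 (within the scatter). At this place, then, 8 heavy atoms with a six-membered aromatic ring replace 1 heavy atom and remove a hydrogen-bond donor, with no step beyond the scatter at this one dose. No measurement is available that bears on this result.

From the compounds shown here alone, whether a smaller group such as methoxy, or hydroxy, which would give a carboxylic acid, on the same carbonyl carbon would produce a step beyond the scatter remains open.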